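The source may hold more compounds than are shown below. What is called first, only, known or untested is meant among the compounds shown, and "the series" means these compounds.

Working notes on the series. All three measured compounds share the core of compound 1 `CCC(=O)N1CC2CC(C1)N2` and differ only in the group on the carbonyl carbon. In an assay on CHO cells for agonist activity at Neuronal acetylcholine receptor; alpha3/alpha6/beta2/beta3 (Homo sapiens), read by FLIPR and calcium flux (on this read-out lower numbers stand for smaller maximal responses and higher numbers for larger maximal responses), compound 1 gives 120%. Compound 2 `O=C(C1CCC1)N1CC2CC(C1)N2` gives 80% in this assay, and compound 3 `O=C([C@H]1C[C@@H]1F)N1CC2CC(C1)N2` gives 85%. Compound 3 thus stands second highest of the three numbers: the step of a number 35 percentage points lower from compound 1 to compound 3 (beyond the scatter) is beyond the scatter, while the step of a number 5 percentage points higher from compound 2 to compound 3 (within the scatter) lies within it, and a number 40 percentage points lower from compound 1 to compound 2 (beyond the scatter) is again beyond the scatter.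

Compound 4 `C[C@@H]1C[C@H]1C(=O)N1CC2CC(C1)N2` differs from compound 3 in one place: 2-methylcyclopropyl in place of 2-fluorocyclopropyl on a carbonyl carbon. Going by the values given here, no measured step swaps one substituent on a cyclopropyl for another. The large steps of a number 40 percentage points lower from compound 1 to compound 2 (beyond the scatter) and a number 35 percentage points lower from compound 1 to compound 3 (beyond the scatter) both concern a ring entering for ethyl, and a number 5 percentage points higher from compound 2 to compound 3 (within the scatter) shows that exchanging one ring group for another on the carbonyl carbon stayed within the scatter. A step within the scatter, a number 3 percentage points lower from compound 3 to compound 4 (within the scatter), is therefore expected. Compound 4 is estimated at 82%, with a range from 62% to 105%.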

Compound 4, largest response reached (Emax), in percent of the reference or control that the assay uses: 110%
Beside the measured number, compound 4's estimate is 28 percentage points below it; the whole stated range lies below it.
By their numbers in this assay, from the lowest: compounds 2 and 3 (each within the scatter of the next); then compounds 4 and 1 (each within the scatter of the next).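

Going by these compounds alone, the ring substituent on the carbonyl carbon matters more than the earlier compounds suggested: in this assay, 2-methylcyclopropyl for 2-fluorocyclopropyl gives a number 25 percentage points higher from compound 3 to compound 4 (beyond the scatter) and 2-methylcyclopropyl for cyclobutyl gives a number 30 percentage points higher from compound 2 to compound 4 (beyond the scatter), so exchanging one ring group for another can move the number beyond the scatter. A ring in place of ethyl also need not lower the read-out, since a number 10 percentage points lower from compound 1 to compound 4 (within the scatter) stands against the large drops seen with compound 2 and compound 3. The two groups leaving and entering in the step to compound 4 match in heavy-atom count and ring, differing in fluorine against carbon, and nothing at hand accounts for the result.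

Still open, as far as these compounds go, is how the read-out responds to other cyclopropyl substituents, such as 2-ethylcyclopropyl or 2-hydroxycyclopropyl, and to unsubstituted cyclopropyl. From the compounds shown here alone, the opposite stereoisomer of 2-methylcyclopropyl also remains open.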